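Swapping the aryl group on the shared core of compound 2

This account rests on a few compounds, and the source may have more. Where it says the series, first, only, none or still open, it means among the compounds named here.

Of the compounds shown here, three sharing one core have been measured in a functional assay on B16-F10 cells (Mus musculus) for inhibition, read by MTT assay, with a stated time of 72 h; a lower number here means a stronger inhibitor, a higher number a weaker inhibitor. Compound 1 `CC(C)c1ccc(-c2nc(SCc3cn(CC(=O)NC(=O)Nc4ccccn4)nn3)nc(Nc3ccccc3Cl)c2C#N)cc1` gives 6790 nM, compound 2 `CC(C)c1ccc(-c2nc(SCc3cn(CC(=O)NC(=O)Nc4ccccn4)nn3)nc(Nc3ccc(Cl)cc3)c2C#N)cc1` gives 860 nM, and compound 3 `Cc1ccc(Nc2nc(SCc3cn(CC(=O)NC(=O)Nc4ccccn4)nn3)nc(-c3ccc(C(C)C)cc3)c2C#N)cc1` gives 3060 nM. Compound 2 stands lowest of the three: the step of a 7.9-fold lower number from compound 1 to compound 2 (0.90 log units; beyond the scatter) and the step of a 3.6-fold higher number from compound 2 to compound 3 (0.55 log units; beyond the scatter) are both beyond the scatter, as is a 2.2-fold lower number from compound 1 to compound 3 (0.35 log units; beyond the scatter). All three of these steps, however, concern the aryl group on the ring nitrogen, not the position changed here.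

Compound 4 `COc1cc(-c2nc(SCc3cn(CC(=O)NC(=O)Nc4ccccn4)nn3)nc(Nc3ccc(Cl)cc3)c2C#N)cc(OC)c1OC` differs from compound 2 by 3,4,5-trimethoxyphenyl in place of 4-isopropylphenyl on an aromatic carbon. Going by the values given here, no measured step touches this position, so none of the steps bears directly on the change, and the data give no direction for it. In the absence of any guide, the number for compound 4 is expected to stay near that of compound 2, with a wide range. Compound 4 is estimated at 1000 nM, between 250 nM and 4000 nM. This estimate means a step of a 1.2-fold higher number from compound 2 to compound 4 (0.07 log units; within the scatter), which is expected to lie within the scatter.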

Compound 4, half-maximal inhibitory concentration: 1110 nM
Compound 4: the middle estimate sits 1.1-fold (0.05 log units) below what was measured; measured number inside the range.
By their numbers in this assay, from the lowest: compounds 2 and 4 (each within the scatter of the next); then compound 3; then compound 1.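

In this assay the change from 4-isopropylphenyl to 3,4,5-trimethoxyphenyl on the aromatic carbon gives a 1.3-fold higher number from compound 2 to compound 4 (0.11 log units; within the scatter) and so leaves the number unmoved, even though the entering group has 12 heavy atoms against 9 and 3 hydrogen-bond acceptors against 0. This position thus accepts this exchange without a step beyond the scatter, whereas the change on the ring nitrogen gives a 7.9-fold lower number from compound 1 to compound 2 (0.90 log units; beyond the scatter) and does go beyond it. Nothing at hand accounts for this lack of change.

On these data alone, both groups compared here are six-membered aromatic rings of carbon only, and it remains open whether the number would hold with a non-aromatic group at this position, such as a morpholine or a simple methyl. As far as these compounds go, it also remains open whether the same exchange would behave alike with the (4-chlorophenyl)amino group replaced by another group.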